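The source may hold more compounds than are shown below. What is called first, only, known or untested is meant among the compounds shown, and "the series" means these compounds.

Measured in a functional assay on MCF7 cells (Homo sapiens) for cytotoxicity, read by MTT assay, with a stated time of 72 h; a higher number here means a weaker inhibitor, a lower number a stronger inhibitor:
compound 1 `Cc1ccc(-c2ccc(C)n2-c2ccc(-c3nc4ccccc4s3)cc2)cc1` gives 3100 nM.
compound 2 `COc1cc(-c2ccc(C)n2-c2ccc(-c3nc4ccccc4s3)cc2)cc(OC)c1OC` gives 4370 nM.
compound 3 `Cc1ccc(-c2ccc(C)n2-c2ccc(-c3nc4ccc(F)cc4s3)cc2)cc1` gives 2970 nM.

Compound 3 differs from compound 1 by fluoro in place of hydrogen on an aromatic carbon, and that step gives a 1.0-fold lower number from compound 1 to compound 3 (0.02 log units; within the scatter). The difference between the core of compound 1 and the core of compound 2 is not broken down here; the two numbers of compound 1 and compound 2 in this assay lie within the scatter of each other, as do those of compound 2 and compound 3. Compound 4 `COc1cc(-c2ccc(C)n2-c2ccc(-c3nc4ccc(F)cc4s3)cc2)cc(OC)c1OC` is not yet measured; it differs from compound 2 by fluoro in place of hydrogen on an aromatic carbon, the same kind of change as from compound 1 to compound 3, at a place described in the same words. Among the measured compounds shown here, the step from compound 2 to compound 4 is expected to be a 1.0-fold lower number from compound 2 to compound 4 (0.01 log units; within the scatter), resting only on the single earlier instance a 1.0-fold lower number from compound 1 to compound 3 (0.02 log units; within the scatter). Compound 4 is accordingly estimated at 4300 nM, with a range from 2400 nM to 7800 nM.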

Compound 4, half-maximal inhibitory concentration: 2360 nM
Compound 4: middle estimate off by 1.8-fold (0.26 log units), on the high side; measured number outside the range, below it.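

In this assay, replacing 1,3-benzothiazol-2-yl with 6-fluoro-1,3-benzothiazol-2-yl on the core of compound 2 gives a 1.9-fold lower number from compound 2 to compound 4 (0.27 log units; within the scatter). Set beside the same change on the core of compound 1, the two steps do not differ beyond the scatter: the same change on two cores in this assay, a 1.0-fold lower number (0.02 log units; within the scatter) from compound 1 to compound 3 and a 1.9-fold lower number (0.27 log units; within the scatter) from compound 2 to compound 4, 1.8-fold (0.25 log units) apart, within the scatter of two such steps. Nothing here indicates that the outcome of this change depends on the core, but each step lies within the scatter, so neither shows a real effect of fluoro, and two cores do not establish a rule for the series.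

From the compounds shown here alone, whether chloro, an amine or a carboxylic acid in place of the fluoro would give a step beyond the scatter stays open. So does the size of this change on any other core.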